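From a Five-Membered Ring to a Carbamoylmethyl Group

A few compounds are considered here, and "the series" means these few. Any claim that something is new, unique, unknown or untested is made for them only; others in the source may bear on it.

Of the compounds shown here, three have so far been measured in an assay on CHO cells for displacement of a labelled ligand from prostaglandin E2 receptor EP3 subtype (Homo sapiens), read by radioligand binding; a higher number here means a weaker inhibitor, a lower number a stronger inhibitor. Compound 1 `CCC(CC)(c1nnc[nH]1)c1ccc(-c2ccc3cc(F)cc(F)c3c2)[nH]c1=O` gives 89 nM, and compound 2 `CCn1ncc2c(F)cc(-c3ccc(C(CC)(CC)c4nncn4C)c(=O)[nH]3)cc21` gives 54 nM. Compound 3 `CC(C)C(c1ccc(-c2ccc3cccc(F)c3c2)[nH]c1=O)N1CCN/C1=N\C#N` gives 23 nM, the lowest number of the three; its gap to compound 2 and its larger gap to compound 1 both lie beyond the scatter, so compound 3 stands as the strongest inhibitor in this set.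

Compound 4 `CC(C)C(CC(N)=O)c1ccc(-c2ccc3cccc(F)c3c2)[nH]c1=O` has not been measured. It differs from compound 3 in one place: a group of 4 heavy atoms (2 carbon, 1 nitrogen, 1 oxygen; no ring) in place of a group of 8 heavy atoms (4 carbon, 4 nitrogen; one five-membered non-aromatic ring with 2 hetero atoms), on a saturated chain carbon bound to an aromatic carbon and a saturated chain carbon. Within the data shown here, no pair of measured compounds differing in a single place exists here, so the size of such a step cannot be read from a measured example, and the expectation rests on the three numbers and the change alone. Compound 4 is expected to be a weaker inhibitor than compound 3, since compound 3 gives 23 nM with the larger group. The step from compound 3 to compound 4 is expected to be a 3.5-fold higher number from compound 3 to compound 4 (0.54 log units; beyond the scatter), beyond the scatter. Compound 4 is estimated at 80 nM, within a range from 25 nM to 300 nM.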

Compound 4, inhibition constant: 5 nM
Estimate against measurement, compound 4: 16-fold (1.20 log units) above; measured number outside the range, below it.
By their numbers in this assay, from the lowest: compound 4; then compound 3; then compounds 2 and 1 (each within the scatter of the next).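

Putting carbamoylmethyl in place of the larger group with its five-membered ring, on this saturated chain carbon, gives a 4.6-fold lower number from compound 3 to compound 4 (0.66 log units; beyond the scatter). Among these compounds, this is the first step read at this position, and it shows that in this assay neither the ring nor its nitrile is needed for a low number here, since a group with no ring and fewer heavy atoms does better. Nothing measured here accounts for the gain.

The compounds shown leave open which part of the carbamoylmethyl group matters, as neither a carboxylic acid or a primary amine in its place nor a longer chain ending in the same amide appears among them. They also leave open whether this group would give a similar step on the cores of compound 1 and compound 2, which carry a different substituent at this carbon.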